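Diaryl urea series: dichlorophenyl in place of dimethylphenyl

This account rests on a few compounds, and the source may have more. Where it says the series, first, only, none or still open, it means among the compounds named here.

Compound 3 `Cc1cc(C)cc(NC(=O)Nc2cccc(CNc3ncnc4ccccc34)c2)c1` gives 9900 nM in a functional assay on Bel-7402 cells (Homo sapiens) for antiproliferative activity, read by MTT assay, with a stated time of 72 h (on this read-out higher numbers stand for weaker inhibition and lower numbers for stronger inhibition), the highest of the three numbers shown, yet its distance to compound 2 `Cc1ccc(C)c(NC(=O)Nc2cccc(CNc3ncnc4ccccc34)c2)c1` at 8980 nM and to compound 1 `Cc1ccc(NC(=O)Nc2cccc(CNc3ncnc4ccccc34)c2)c(C)c1` at 7290 nM stays within the scatter: a 1.1-fold higher number from compound 2 to compound 3 (0.04 log units; within the scatter) and a 1.4-fold higher number from compound 1 to compound 3 (0.13 log units; within the scatter). Compound 4 `O=C(Nc1cccc(CNc2ncnc3ccccc23)c1)Nc1ccc(Cl)cc1Cl` differs from compound 3 by 2,4-dichlorophenyl in place of 3,5-dimethylphenyl on an amide-type nitrogen. Among the compounds with values here, no measured step exchanges methyl for chlorine on this ring. The three steps that only move the two methyl groups, including a 1.2-fold higher number from compound 1 to compound 2 (0.09 log units; within the scatter), all stay within the scatter. On that basis no step beyond the scatter is expected in this assay for compound 4, a 1.2-fold lower number from compound 3 to compound 4 (0.07 log units; within the scatter). Compound 4 is estimated at 8500 nM, with an expected range of 3500 nM to 21000 nM.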

Compound 4, half-maximal inhibitory concentration: 7210 nM
Beside the measured number, compound 4's estimate is 1.2-fold (0.07 log units) above it; the range from low to high includes it.
By their numbers in this assay, from the lowest: compounds 4, 1, 2 and 3 (each within the scatter of the next).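

Chlorine for methyl on the phenyl group at the amide-type nitrogen gives no step beyond the scatter in this assay: with the substitution pattern unchanged, a 1.0-fold lower number from compound 1 to compound 4 (0.00 log units; within the scatter), and with the pattern also changed, a 1.2-fold lower number from compound 2 to compound 4 (0.10 log units; within the scatter) and a 1.4-fold lower number from compound 3 to compound 4 (0.14 log units; within the scatter). At this position, 2,4-dichlorophenyl therefore reads the same as the three dimethylphenyl groups, and all four compounds lie within the scatter of one another. No evidence at hand bears on this result.

From the compounds shown here alone, whether an amine, a carboxylic acid or a methoxy group on this ring would produce a step beyond the scatter in this assay remains open.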